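From fluoro to trifluoromethyl at one aromatic carbon

The compounds below may be only part of what the source reports. "The series", "measured", "known", "first", "only" and "open" are said of these compounds alone.

Three compounds share one core and differ in a single group on an aromatic carbon: compound 1 `Cc1ccc(NS(=O)(=O)c2cccc(CCCCCCNC(=O)/C=C/c3cccnc3)c2)cc1` carries methyl, compound 2 `CC(C)(C)c1ccc(NS(=O)(=O)c2cccc(CCCCCCNC(=O)/C=C/c3cccnc3)c2)cc1` carries tert-butyl and compound 3 `O=C(/C=C/c1cccnc1)NCCCCCCc1cccc(S(=O)(=O)Nc2ccc(F)cc2)c1` carries fluoro. In a functional assay on HeLa cells (Homo sapiens) for inhibition, read by CCK-8 assay, with a stated time of 72 h (a higher number here means a weaker inhibitor, a lower number a stronger inhibitor), compound 1 gives 38.8 nM, compound 2 gives 1520 nM and compound 3 gives 99.9 nM, which places compound 3 in the middle of the three. Compound 4 `O=C(/C=C/c1cccnc1)NCCCCCCc1cccc(S(=O)(=O)Nc2ccc(C(F)(F)F)cc2)c1` has trifluoromethyl in place of fluoro on that carbon (trifluoromethyl in place of fluoro on an aromatic carbon). Within the data shown here, no measured compound carries this group, so the guidance is indirect. Swapping methyl for fluoro gave a modest step, a 2.6-fold higher number from compound 1 to compound 3 (0.41 log units; beyond the scatter). The steps involving tert-butyl were large: a 39-fold higher number from compound 1 to compound 2 (1.59 log units; beyond the scatter) and a 15-fold lower number from compound 2 to compound 3 (1.18 log units; beyond the scatter). Trifluoromethyl, like tert-butyl, is a branched group, but compound 2 at 1520 nM is only one example, so a moderate rise seems more likely than a full one. In this assay the expected change is a 3.0-fold higher number from compound 3 to compound 4 (0.48 log units; beyond the scatter). For compound 4 the estimated value is 300 nM, with an expected range of 90 nM to 1000 nM.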

Compound 4, half-maximal inhibitory concentration: 1450 nM
Compound 4: the middle estimate sits 4.8-fold (0.68 log units) below what was measured, and the stated range ends below it.
By their numbers in this assay, from the lowest: compound 1; then compound 3; then compounds 4 and 2 (each within the scatter of the next).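

At this para carbon, trifluoromethyl behaves nothing like the fluoro it replaces: in this assay the change carries a large penalty (a 15-fold higher number from compound 3 to compound 4 (1.16 log units; beyond the scatter)). Compound 4 cannot be told apart from the tert-butyl compound (a 1.0-fold lower number from compound 2 to compound 4 (0.02 log units; within the scatter)), and it stands well away from the methyl compound (a 37-fold higher number from compound 1 to compound 4 (1.57 log units; beyond the scatter)), so among these four compounds the two branched groups give the high numbers and methyl and fluoro the low numbers, with no compound going against this. No measurement at hand explains this pattern.

Going by these compounds, it remains open whether branching itself matters or whether an unbranched group such as ethyl or methoxy at this carbon would give similarly high numbers. A chloro group or a nitrile there would also show how sharply the numbers rise from fluoro to trifluoromethyl.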